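Meta substituent series: from dimethylamino to cyano

The source may hold more compounds than are shown below. What is called first, only, known or untested is meant among the compounds shown, and "the series" means these compounds.

Among the compounds with values here, in a functional assay with Rattus norvegicus as the target (a lower number here means a stronger inhibitor, a higher number a weaker inhibitor), compound 3 `CN(C)c1cccc(C(=O)/C=C/c2ccncc2)c1` gives 19000 nM, the lowest of the three numbers so far; compound 1 `O=C(/C=C/c1ccncc1)c1cccc(C(F)(F)F)c1` gives 41000 nM and compound 2 `O=C(/C=C/c1ccncc1)c1cccc(Cl)c1` gives 69000 nM. Compound 4 `N#Cc1cccc(C(=O)/C=C/c2ccncc2)c1` differs from compound 3 by cyano in place of dimethylamino on an aromatic carbon. Within the data shown here, the steps that bear on this change are a 2.2-fold lower number from compound 1 to compound 3 (0.33 log units; beyond the scatter) and a 3.6-fold lower number from compound 2 to compound 3 (0.56 log units; beyond the scatter), both modest drops where dimethylamino entered, while a 1.7-fold higher number from compound 1 to compound 2 (0.23 log units; within the scatter) shows the two other groups sitting close together. For compound 4 the change is therefore expected to undo those modest drops, giving a higher number in this assay of the size a 2.4-fold higher number from compound 3 to compound 4 (0.37 log units; beyond the scatter). The estimate for compound 4 is 45000 nM, with a range from 20000 nM to 100000 nM.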

Compound 4, half-maximal inhibitory concentration: 85000 nM
Beside the measured number, compound 4's estimate is 1.9-fold (0.28 log units) below it; the range from low to high includes it.
By their numbers in this assay, from the lowest: compound 3; then compounds 1, 2 and 4 (each within the scatter of the next, the first and the last beyond it).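

In this assay, within the data shown here, the largest step at this position so far is a 4.5-fold higher number from compound 3 to compound 4 (0.65 log units; beyond the scatter) and dimethylamino remains the only group clearly set apart from the other three. Cyano cannot be separated from chloro (a 1.2-fold higher number from compound 2 to compound 4 (0.09 log units; within the scatter)), yet it does part from trifluoromethyl (a 2.1-fold higher number from compound 1 to compound 4 (0.32 log units; beyond the scatter)), although chloro and trifluoromethyl lie within the scatter of each other. No measurement on these compounds accounts for these differences. Open, as far as these compounds go, is whether the low number belongs to dimethylamino alone or also extends to a primary amine or a morpholine at this place. A carboxylic acid at this place is equally unresolved.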